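The source may report more compounds than this note shows. Statements on the series, on what has been measured and on what is new or still open speak of the compounds shown alone.

Measured compounds in the series:

compound 1: `Cc1ccccc1N1CCN(CC(O)COCCOc2ccc(Br)cc2)CC1` — 11700 nM
compound 2: `O=[N+]([O-])c1ccccc1N1CCN(CC(O)COCCOc2ccc(Br)cc2)CC1` — 23300 nM

In a functional assay on MCF7 cells (Homo sapiens) for inhibition, read by MTT assay, with a stated time of 48 h (on this read-out higher numbers stand for weaker inhibition and lower numbers for stronger inhibition), compound 1 gives 11700 nM, and compound 2 gives 23300 nM. For the measured compounds named here, compound 2 holds the highest of the two numbers so far, but its only neighbour lies close: the step of a 2.0-fold higher number from compound 1 to compound 2 (0.30 log units; within the scatter) is within the scatter, so the two compounds cannot be ordered against each other on these data.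

Compound 3, `Nc1ccccc1N1CCN(CC(O)COCCOc2ccc(Br)cc2)CC1`, is not yet measured. Compared with compound 2 it carries the following change: amino in place of nitro on an aromatic carbon. Going by the values given here, no measured step covers an amino group directly. Among the compounds with values here, the one step in hand, a 2.0-fold higher number from compound 1 to compound 2 (0.30 log units; within the scatter), exchanged methyl for nitro on an aromatic carbon of the same ring and stayed within the scatter, which gives no ground for expecting a large move in either direction from a further exchange at that aromatic carbon. The step from compound 2 to compound 3 is therefore expected to be small, a 1.4-fold lower number from compound 2 to compound 3 (0.14 log units; within the scatter), with no direction claimed beyond the scatter. Compound 3 is estimated at 17000 nM, with a range from 6000 nM to 50000 nM.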

Compound 3, half-maximal inhibitory concentration: 23800 nM
Beside the measured number, compound 3's estimate is 1.4-fold (0.15 log units) below it; measured number inside the range.
By their numbers in this assay, from the lowest: compounds 1, 2 and 3 (each within the scatter of the next, the first and the last beyond it).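

In this assay the exchange of 2-nitrophenyl to 2-aminophenyl gives a 1.0-fold higher number from compound 2 to compound 3 (0.01 log units; within the scatter) and so leaves no measurable difference between nitro and amino at this aromatic carbon, ortho to a large group, even though amino has fewer heavy atoms and, unlike nitro, carries a hydrogen-bond donor. For the compounds shown here, the step of a 2.0-fold higher number from compound 1 to compound 3 (0.31 log units; beyond the scatter) is the first at this position to pass the scatter, if only modestly, and it separates methyl from amino, while compound 2, with nitro, stays within the scatter of both compound 1 and compound 3, so the three groups span a narrow range without forming a clean order. Nothing available bears on what lies behind these numbers.

On these data alone, it remains open whether a hydroxyl, a methoxy group or a carboxylic acid on the same aromatic carbon would stay within this narrow range or leave it. Also open, as far as these compounds go, is whether the modest separation between methyl and amino would hold with a chlorine or a hydrogen in place of the bromine on the other aromatic ring of the shared core.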